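This account rests on a few compounds, and the source may have more. Where it says the series, first, only, none or still open, it means among the compounds named here.

Compound 1 `Cc1ccc2c(c1)/C(=N/N=C/c1ccco1)C(=O)N2` gives 8750 nM
Compound 2 `O=C1Nc2ccc(Cl)cc2/C1=N/N=C/c1ccco1` gives 7750 nM
Compound 3 `Cc1ccc2c(c1)/C(=N/N=C/c1cccs1)C(=O)N2` gives 6750 nM

These three numbers come from a functional assay on MCF7 cells (Homo sapiens) for cytotoxicity, read by sulforhodamine B assay, with a stated time of 48 h; on this read-out higher numbers stand for weaker inhibition and lower numbers for stronger inhibition. All three sit close together, and no one of them can be called stronger or weaker than another on this evidence. From compound 1 to compound 2 the change is chloro in place of methyl on an aromatic carbon, and the step it made was a 1.1-fold lower number from compound 1 to compound 2 (0.05 log units; within the scatter). Compound 3 differs from compound 1 in its core: thiophen-2-yl in place of furan-2-yl on a carbon with a double bond to nitrogen. The step there was a 1.3-fold lower number from compound 1 to compound 3 (0.11 log units; within the scatter).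

Compound 4 `O=C1Nc2ccc(Cl)cc2/C1=N/N=C/c1cccs1` has not yet been measured in this assay. It differs from compound 3 by chloro in place of methyl on an aromatic carbon. This is the same change as from compound 1 to compound 2, made on the core of compound 3 rather than the core of compound 1. For compound 4 the expected step is a 1.1-fold lower number from compound 3 to compound 4 (0.05 log units; within the scatter), because a 1.1-fold lower number from compound 1 to compound 2 (0.05 log units; within the scatter) stayed within the scatter and nothing here suggests the new core would behave differently. Compound 4 is therefore estimated at 6000 nM, with a likely range from 3000 nM to 12000 nM.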

Compound 4, half-maximal inhibitory concentration: 15300 nM
The estimate for compound 4 lay 2.6-fold (0.41 log units) below the measured number, and the stated range ends below it.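

Moved to a second core in this assay, chloro in place of methyl gave a 2.3-fold higher number from compound 3 to compound 4 (0.36 log units; beyond the scatter), and thiophen-2-yl in place of furan-2-yl, also on a new core, gave a 2.0-fold higher number from compound 2 to compound 4 (0.30 log units; within the scatter). The chloro change looks larger on its second core, but the gap between its two steps cannot be told apart from ordinary scatter, so the data show neither that its outcome depends on the core nor that it carries over unchanged: the same change on two cores in this assay, a 1.1-fold lower number (0.05 log units; within the scatter) from compound 1 to compound 2 and a 2.3-fold higher number (0.36 log units; beyond the scatter) from compound 3 to compound 4, 2.6-fold (0.41 log units) apart, within the scatter of two such steps. The change from furan-2-yl to thiophen-2-yl must be read the same cautious way: the same change on two cores in this assay, a 1.3-fold lower number (0.11 log units; within the scatter) from compound 1 to compound 3 and a 2.0-fold higher number (0.30 log units; within the scatter) from compound 2 to compound 4, 2.6-fold (0.41 log units) apart, within the scatter of two such steps.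

Going by these compounds alone, with only two groups on the aromatic carbon and two rings on the carbon with a double bond to nitrogen, this small square of compounds cannot say how far either comparison extends. It leaves open what an amine or a methoxy group would do on that aromatic carbon, or a phenyl ring in place of the furan-2-yl or thiophen-2-yl group.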